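Chloro to Methyl: Expected Cytotoxicity of Compound 4

This account rests on a few compounds, and the source may have more. Where it says the series, first, only, none or still open, it means among the compounds named here.

Compound 1 `O=C1CSC(c2ccc(Cl)cc2)N1CCN1CCCCC1` is tested in an ADME assay on Vero cells (Chlorocebus sabaeus) for cytotoxicity, read by neutral red uptake, tested at 3150 ug/mL (a higher number here means a weaker effect of the compound at the concentration tested, a lower number a stronger effect), where compound 1 gives 11%. Compound 2 `COc1ccc(C2SCC(=O)N2CCN2CCCCC2)cc1` gives 11%, and compound 3 `O=C1CSC(c2ccccc2[N+](=O)[O-])N1CCN1CCCCC1` gives 30%. Compound 1 thus stands level with compound 2, the two together being the lowest of the three numbers, while compound 3 lies higher by an amount beyond the scatter. Compound 4 `Cc1ccc(C2SCC(=O)N2CCN2CCCCC2)cc1` differs from compound 1 by methyl in place of chloro on an aromatic carbon. Among the compounds with values here, the one measured step that bears on this change, no change at the digits printed from compound 1 to compound 2 (within the scatter), also swapped the chloro for another small group on the same aromatic carbon and brought no change within the scatter. The expected step is therefore none beyond the scatter: a number 1 percentage points higher from compound 1 to compound 4 (within the scatter). Compound 4 is estimated to give 12%, expected within 4% to 24%.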

Compound 4, a percentage reported as activity, at one concentration (the size of the read-out at that concentration, not a potency): 12%
For compound 4 middle estimate and measured number coincide at the digits printed; low and high end bracket the measured number.
By their numbers in this assay, from the lowest: compounds 1, 2 and 4 (each within the scatter of the next); then compound 3.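

In this assay, methyl in place of chloro gives a number 1 percentage points higher from compound 1 to compound 4 (within the scatter), and methyl in place of methoxy gives a number 1 percentage points higher from compound 2 to compound 4 (within the scatter). Methyl is thus a third group, after chloro and methoxy, that reads level on this aromatic carbon, para to a large group, so these three compounds draw no distinction among the groups tested here. Nothing available explains this level reading. From the compounds shown here alone, whether an amine, a carboxylic acid or a longer chain at the same place would stay level with these three remains open.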